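The compounds below may be only part of what the source reports. "The series", "measured", "known", "first", "only" and "open" are said of these compounds alone.

Compound 1 `CCC[C@@H](OC(C)=O)C1=C(Br)[C@@](C)(OC)OC1=O` is one of three compounds that have been measured in a functional assay on LNCaP cells (Homo sapiens) for cytotoxicity; a lower number here means that less compound is needed, a higher number that more compound is needed for the effect. Compound 1 gives 1.7 ug/mL, the lowest of the three numbers. Compound 2 `CCC[C@@H](OC(C)=O)C1=C(Br)[C@@](CI)(OC)OC1=O` gives 12.9 ug/mL, and compound 3 `CCCCC1=C(Br)/C(=C/Br)OC1=O` gives 7.3 ug/mL. For the measured compounds named here, the only single-point change that has been measured is a 7.6-fold higher number from compound 1 to compound 2 (0.88 log units; beyond the scatter), where an iodo replaces a hydrogen on a saturated chain carbon bound to a saturated ring carbon.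

Compound 4 `CCC[C@@H](OC(C)=O)C1=C(Br)[C@](C)(OC)OC1=O` has not yet been measured. The change from compound 1 to compound 4 is the two compounds have the same atoms and bonds and differ only in configuration as drawn: 1 of 2 stereo elements differ; a stereocentre at a saturated ring carbon is drawn S in compound 1 and R in compound 4. Going by the values given here, no measured pair differs by configuration alone, so nothing here shows how this assay responds to such a change; the iodo for hydrogen exchange is a different kind of change and does not bear on it. The estimated step of a 1.5-fold higher number from compound 1 to compound 4 (0.17 log units; within the scatter) is expected to be small and may well fall within the scatter. Compound 4 is therefore estimated at 2.5 ug/mL, with a range from 1 ug/mL to 8 ug/mL.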

Compound 4, concentration for half-maximal effect: 3.6 ug/mL
Compound 4: the middle estimate sits 1.4-fold (0.16 log units) below what was measured; measured number inside the range.
By their numbers in this assay, from the lowest: compound 1; then compound 4; then compounds 3 and 2 (each within the scatter of the next).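

For the compounds shown here, this is the first measured pair that isolates configuration from every other change, and this assay does respond to it, with a 2.1-fold higher number from compound 1 to compound 4 (0.33 log units; beyond the scatter). The step is modest, but it shows that the number depends on how the groups are arranged in space at this saturated ring carbon, and not only on which atoms are present. The difference can be traced to that one stereocentre because nothing else changes: the fact that compounds 1 and 4 differ only in the configuration as drawn.

The compounds shown leave open whether the S configuration would still give the lower number with the iodo group of compound 2 in place, and what the second stereocentre contributes. They also leave open how the number would respond if an amine or a carboxylic acid took the place of the acetate ester.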